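The source may report more compounds than this note shows. Statements on the series, on what has been measured and on what is new or still open speak of the compounds shown alone.

Measured in a functional assay on A549 cells (Homo sapiens) for cytotoxicity, read by sulforhodamine B assay; a higher number here means a weaker inhibitor, a lower number a stronger inhibitor:
- Compound 1 `O=C1c2cccc3c2c(cc2c4ccccc4sc32)C(=O)N1CN1CCNCC1`: 11800 nM
- Compound 2 `CCCCN1C(=O)c2cccc3c2c(cc2c4ccccc4oc32)C1=O`: 1400 nM
- Compound 3 `CN(C)CCCN1C(=O)c2cccc3c2c(cc2c4ccccc4oc32)C1=O`: 740 nM

In this assay, compound 3 gives 740 nM, within the scatter of compound 2, and compound 1 has a clearly higher number. Compound 4 `O=C1c2cccc3c2c(cc2c4ccccc4oc32)C(=O)N1CN1CCNCC1` keeps the core of compound 3, with this change: piperazin-1-yl in place of 2-(dimethylamino)ethyl on a saturated chain carbon bound to an amide-type nitrogen in a ring. Among the compounds with values here, the only measured step on this chain, a 1.9-fold lower number from compound 2 to compound 3 (0.28 log units; within the scatter), is within the scatter and does not involve a piperazin-1-yl group. Compound 1, which carries the same (piperazin-1-yl)methyl on a different core, gives 11800 nM, so a higher number is expected, though its size is uncertain. The estimated step is a 5.4-fold higher number from compound 3 to compound 4 (0.73 log units; beyond the scatter). For compound 4 the expected value is 4000 nM, with an estimated range of 1200 nM to 13000 nM.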

Compound 4, half-maximal inhibitory concentration: > 100000 nM
Compound 4 gave a limit, no number; the forecaster's own chance of this, stated with the estimate: 3%; middle value at least 25-fold (1.39 log units) away from the limit.
By their numbers in this assay, from the lowest: compounds 3 and 2 (each within the scatter of the next); then compound 1. At a limit, above all of these: compound 4.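

In this assay, compound 4 gives a limit and not a number: the limit of > 100000 nM in this assay, at which 1 of the 4 values shown sits.

The change on this saturated chain carbon gives an at least 130-fold higher number from compound 3 to compound 4 (2.13 log units; beyond the scatter) and an at least 71-fold higher number from compound 2 to compound 4 (1.85 log units; beyond the scatter), whereas the earlier step on this chain, a 1.9-fold lower number from compound 2 to compound 3 (0.28 log units; within the scatter), showed no such effect. Compound 1, with the same (piperazin-1-yl)methyl on a different core, still gives 11800 nM, so this group does not rule out a measured number on every core.

The compounds shown do not separate the piperazin-1-yl ring from the change from 3-(dimethylamino)propyl to (piperazin-1-yl)methyl. A 3-(piperazin-1-yl)propyl chain or a (dimethylamino)methyl group on the core of compound 4 would separate them.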